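Methyl removal in a small whole-organism inhibition series

A few compounds are considered here, and "the series" means these few. Any claim that something is new, unique, unknown or untested is made for them only; others in the source may bear on it.

Measured so far, in a functional assay on the whole organism for inhibition, with Rattus norvegicus as the target, at a dose of 30 mg/kg; on this read-out higher numbers stand for more inhibition at the one dose given (going by the name of the read-out) and lower numbers for less inhibition:
compound 1, `Cc1ccc(-c2nc3ncccc3o2)cc1`, gives 5%
compound 2, `Clc1ccc(-c2nc3cccnc3o2)cc1`, gives 14%

Compound 1 stands at the lower of the two numbers in this assay; its nearest neighbour, compound 2, lies higher by an amount within the scatter, so the two are not distinguished. Among the measured compounds shown here, no step between measured compounds with a single change is available.

Compound 3, `c1ccc(-c2nc3ncccc3o2)cc1`, is the unmeasured member. Its difference from compound 1 is hydrogen in place of methyl on an aromatic carbon. For the measured compounds named here, the only guide is that compound 1 gives 5% and compound 2 gives 14%, both small numbers on this read-out; nothing here suggests that losing the methyl moves the number beyond the scatter. The step from compound 1 to compound 3 is expected to be a number 3 percentage points higher from compound 1 to compound 3 (within the scatter), which is no more than the usual scatter. Compound 3 is therefore estimated at 8%, with a range from -5% to 25%.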

Compound 3, a percentage reported as inhibition, in the whole organism at one dose (the size of the read-out at that dose, not a potency): 41%
Estimate against measurement, compound 3: 33 percentage points below; the whole stated range lies below it.
By their numbers in this assay, from the lowest: compounds 1 and 2 (each within the scatter of the next); then compound 3.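

Hydrogen in place of methyl on this aromatic carbon, para to a group of 9 heavy atoms, gives a number 36 percentage points higher from compound 1 to compound 3 (beyond the scatter) in this assay, so this position is not indifferent to a change of only 1 carbon. Among the compounds shown here, compound 2 differs from compound 3 in more than one place and gives no reading of this position, which leaves this one step as the only evidence on it. Nothing available bears on why the step is so large.

Still open, on these data alone, is whether the number at this position depends on the methyl alone or falls with any group there, such as a methoxy group, a fluorine atom or an ethyl chain on the core of compound 3. With only one dose given, the step also leaves open how the compounds would rank at other doses.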